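Second chloro on the core of compound 2

The compounds below may be only part of what the source reports. "The series", "measured", "known", "first", "only" and "open" are said of these compounds alone.

Measured compounds:
compound 1, `ClCc1ccccc1Cn1cnc2ncnc(Cl)c21`, 2290 nM
compound 2, `ClCc1ccc(Cn2cnc3ncnc(Cl)c32)cc1`, 1730 nM

In a functional assay on Hs-578T cells (Homo sapiens) for cytotoxicity, read by sulforhodamine B assay, with a stated time of 48 h (a higher number here means a weaker inhibitor of growth, a lower number a stronger inhibitor of growth), compound 2 gives 1730 nM. Compound 1 gives 2290 nM in this assay. For the measured compounds named here, the two values lie within the usual scatter of each other, so the data do not set compound 2 apart from compound 1; no step between the two measured compounds is given, and nothing more can be said of their pair than what the two numbers show.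

Compound 3, `ClCc1ccc(Cn2cnc3nc(Cl)nc(Cl)c32)cc1`, has not yet been measured in this assay. It differs from compound 2 in one place: chloro in place of hydrogen on an aromatic carbon. Going by the values given here, no measured pair in this set shows what a second chloro on the core does, so the expectation rests only on the two numbers at hand and on the change being a single heavy atom. A step from compound 2 to compound 3 of about a 1.4-fold lower number from compound 2 to compound 3 (0.16 log units; within the scatter) is expected, toward a lower number but hardly beyond the scatter. For compound 3 the estimate in this assay is 1200 nM, with a range from 400 nM to 4000 nM.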

Compound 3, concentration for 50% growth inhibition: 19100 nM
For compound 3 the middle estimate is 16-fold (1.20 log units) below the measured one; measured number above the stated range.
By their numbers in this assay, from the lowest: compounds 2 and 1 (each within the scatter of the next); then compound 3.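

The chloro that enters on the aromatic carbon between two ring nitrogen atoms adds a single heavy atom, yet in this assay it brings an 11-fold higher number from compound 2 to compound 3 (1.04 log units; beyond the scatter), a large step toward weaker inhibition of growth. Compound 1 and compound 2 both carry hydrogen at this place on the shared core, so they said nothing about it; this step shows that the position does not tolerate every change, and that replacing hydrogen with chloro here goes with a clear loss of growth inhibition. Nothing in the data shown accounts for the size of this step, which stands as an observation on a single pair of compounds.

As far as these compounds go, whether the loss belongs to chloro in particular or would follow any group at this position remains open, and an amine, a methyl group or a methoxy group on the same carbon would help to separate these two readings. From the compounds shown here alone, it is also open whether the step carries over to the core of compound 1, where the chloromethyl group sits elsewhere on the benzene ring.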